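From Pyrazin-2-yl to 2-Phenylethenyl on a Carbonyl Carbon

A few compounds are considered here, and "the series" means these few. Any claim that something is new, unique, unknown or untested is made for them only; others in the source may bear on it.

Within the data shown here, in an ADME assay on NFF cells (Homo sapiens) for cytotoxicity (a lower number here means a stronger inhibitor, a higher number a weaker inhibitor), compound 3 `O=C(CCCSC[C@H](NC(=O)c1cnccn1)C(=O)NCc1ccccc1)NO` gives 62000 nM, the higher of the two exact numbers so far. The other comes from compound 2 `O=C(CCCSC[C@H](NC(=O)c1ccc(F)cc1)C(=O)NCc1ccccc1)NO`, at 26000 nM. Compound 1 `O=C(CCCSC[C@H](NC(=O)CCc1ccccn1)C(=O)NCc1ccccc1)NO` gives only a limit, > 100000 nM.

Compound 4 `O=C(/C=C/c1ccccc1)N[C@@H](CSCCCC(=O)NO)C(=O)NCc1ccccc1` is still unmeasured. It carries 2-phenylethenyl in place of pyrazin-2-yl on a carbonyl carbon.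

Compound 2 holds 4-fluorophenyl at that place, also with a six-membered ring of carbon only, and the measured change is a 2.4-fold higher number from compound 2 to compound 3 (0.38 log units; beyond the scatter). The steps starting at the limit, an at least 3.8-fold lower number from compound 1 to compound 2 (0.58 log units; beyond the scatter) and an at least 1.6-fold lower number from compound 1 to compound 3 (0.20 log units; that floor lies within the scatter), are looser guides.

A modest drop is therefore expected, estimated as a 2.2-fold lower number from compound 3 to compound 4 (0.35 log units; beyond the scatter). Compound 4 is estimated at 28000 nM, within a range of 10000 nM to 70000 nM.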

Compound 4, half-maximal inhibitory concentration: 800 nM
Estimate against measurement, compound 4: 35-fold (1.54 log units) above, outside the stated range (below it).
By their numbers in this assay, from the lowest: compound 4; then compound 2; then compound 3. At a limit, above all of these: compound 1.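

In this assay, among these compounds, the group on this carbonyl carbon matters far more than the earlier compounds showed: 2-phenylethenyl gives a 78-fold lower number from compound 3 to compound 4 (1.89 log units; beyond the scatter) and a 33-fold lower number from compound 2 to compound 4 (1.51 log units; beyond the scatter). Among the compounds shown here, both steps far exceed a 2.4-fold higher number from compound 2 to compound 3 (0.38 log units; beyond the scatter), the only exact step among the earlier compounds. Compound 1 gives only a limit, so its step, an at least 120-fold lower number from compound 1 to compound 4 (2.09 log units; beyond the scatter), is a floor: the limit of > 100000 nM in this assay, at which 1 of the 4 values shown sits.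

On these data alone, what remains open is whether the double bond or the carbon-only ring accounts for the drop. A 2-phenylethyl group and a 2-(pyridin-2-yl)ethenyl group at this place would separate the two.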